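This account rests on a few compounds, and the source may have more. Where it says the series, first, only, none or still open, it means among the compounds named here.

In the measurements at hand, two compounds share a core and differ only in what sits on the aromatic ring carrying the urea. Compound 1 `O=C(Nc1ccncc1)Nc1ccccc1C(F)(F)F` is measured in a functional assay on the whole organism with Mus musculus as the target, in the maximal electroshock model, with a stated time of 30 min (a lower number here means that less compound is needed, a higher number that more compound is needed for the effect), and gives 100 mg/kg. Compound 2 `Cc1cccc(Cl)c1NC(=O)Nc1ccncc1` gives 30 mg/kg in this assay, which is the lowest of the two numbers shown; the gap from compound 1 to compound 2 lies beyond the usual scatter of the method, so compound 2 stands as the better of the two on these figures.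

Compound 3 `O=C(Nc1ccncc1)Nc1c(Cl)cccc1C(F)(F)F` is the next compound and has not yet been measured. It differs from compound 2 in one place: trifluoromethyl in place of methyl on an aromatic carbon. The trifluoromethyl group of compound 3 sits ortho to a large group and meta to a chloro group, so compound 3 combines the trifluoromethyl seen in compound 1 with the chloro seen in compound 2.

Within the data shown here, no measured pair shows this change directly. Given that compound 1 with its trifluoromethyl gives 100 mg/kg while compound 2 gives 30 mg/kg, a small loss is expected, with the step from compound 2 to compound 3 estimated at a 1.7-fold higher number from compound 2 to compound 3 (0.22 log units; within the scatter), which may still fall within the scatter. Compound 3 is therefore expected to give 50 mg/kg in this assay, within a range from 20 mg/kg to 150 mg/kg.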

Compound 3, minimum effective dose: 100 mg/kg
Compound 3: middle estimate off by 2.0-fold (0.30 log units), on the low side; the measured number falls inside the stated range.
By their numbers in this assay, from the lowest: compound 2; then compounds 1 and 3 (each within the scatter of the next).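

In this assay, among these compounds, the exchange of trifluoromethyl in place of methyl on this aromatic carbon, which no earlier pair could show, gives a 3.3-fold higher number from compound 2 to compound 3 (0.52 log units; beyond the scatter) and so counts as a modest step against trifluoromethyl at this position in the presence of the chloro group. The other new step, chloro in place of hydrogen on an aromatic carbon, gives no change at the digits printed from compound 1 to compound 3 (within the scatter) in the same assay, so with trifluoromethyl on the ring the added chloro brings no readable shift, and the advantage of compound 2 over compound 3 follows the methyl in this one pair. No measurement at hand offers a reason for either step.

What the compounds shown leave open is how much of the number of compound 2 rests on its chloro, as chloro in place of hydrogen is read here only with trifluoromethyl present. As far as these compounds go, they also do not tell how this aromatic carbon would respond to a methoxy group, an amine, a nitrile or a longer chain such as ethyl, so the reach of the methyl result beyond this single exchange remains unknown.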